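The source may report more compounds than this note shows. Statements on the series, on what has been measured and on what is new or still open speak of the compounds shown alone.

Values so far in an ADME assay on Vero cells (Chlorocebus sabaeus) for cytotoxicity, read by crystal violet staining; a higher number here means that more compound is tolerated, a lower number that less compound is tolerated (compound 3 still open)
- compound 1 `Cc1ccc(/N=N/N(C)c2ccccc2)cc1` gives 58000 nM
- compound 2 `CN(C)CCCN(/N=N/c1ccc([N+](=O)[O-])cc1)c1ccccc1` gives 40000 nM
- compound 3 `CN(/N=N/c1ccccc1)c1ccccc1` has no value yet

Compound 1 has only compound 2 as a neighbour on the numbers, and the two values lie within the usual scatter of each other, so neither stands apart in this assay.

The next step goes from compound 1 to compound 3: hydrogen in place of methyl on an aromatic carbon, para to a large group (hydrogen in place of methyl on an aromatic carbon). Going by the values given here, no step between measured compounds that differ in one place is available, so the size of this step cannot be read from the series. The change is small, and no shift beyond the scatter is expected. The estimated change is a 1.1-fold lower number from compound 1 to compound 3 (0.02 log units; within the scatter). For compound 3 the expected value is 55000 nM, with an estimated range of 25000 nM to 120000 nM.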

Compound 3, half-maximal cytotoxic concentration: 50000 nM
Compound 3: the middle estimate sits 1.1-fold (0.04 log units) above what was measured; the measured number falls inside the stated range.
By their numbers in this assay, from the lowest: compounds 2, 3 and 1 (each within the scatter of the next).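

In this assay, going by these compounds alone, the one single-place comparison gives a 1.2-fold lower number from compound 1 to compound 3 (0.06 log units; within the scatter), so compounds 1 and 3 cannot be told apart. The earlier compounds shown here offered no such comparison; this one shows that, on this core, hydrogen in place of methyl on an aromatic carbon, para to a large group, leaves the number within the scatter. Nothing at hand bears on the reason for this result.

The compounds shown compare only methyl and hydrogen at this position, so the outcome with an amine, a carboxylic acid or a longer chain there remains open. Also open, from the compounds shown here alone, is whether the same replacement would read alike on the core of compound 2, which carries a dimethylaminopropyl chain and a nitro group.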